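Formyl in Place of Methoxy: An Expected Small Step

The source may report more compounds than this note shows. Statements on the series, on what has been measured and on what is new or still open speak of the compounds shown alone.

Measured so far in a functional assay on SK-OV-3 cells (Homo sapiens) for inhibition, read by CCK-8 assay, with a stated time of 70 h; a higher number here means a weaker inhibitor, a lower number a stronger inhibitor:
Compound 1 `COc1ccc(COc2ccc(OCCOCCNC3CCCC3)cc2)cc1` gives 15700 nM.
Compound 2 `O=[N+]([O-])c1ccccc1COc1ccc(OCCOCCNC2CCCCC2)cc1` gives 2880 nM.
Compound 3 `c1ccc(COc2ccc(OCCOCCNC3CCCCCC3)cc2)cc1` gives 7460 nM.

Among these three, compound 1 has the highest number in this assay; compound 3 comes nearest to it and compound 2 lies furthest from it, and both gaps are beyond the usual scatter. The untested compound 4 `O=Cc1ccc(COc2ccc(OCCOCCNC3CCCC3)cc2)cc1` differs from compound 1 in one place: formyl in place of methoxy on an aromatic carbon. Within the data shown here, no pair of measured compounds differs only in this way, so there is no direct guide to the size of the step. Compound 2 and compound 3 also carry a different ring on the amine, so their values say nothing about this swap alone. The change is expected to be small, a 1.6-fold lower number from compound 1 to compound 4 (0.20 log units; within the scatter), within the scatter or slightly toward a lower number. Compound 4 is therefore estimated at 10000 nM, with a range from 3000 nM to 30000 nM.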

Compound 4, half-maximal inhibitory concentration: 45000 nM
Compound 4: middle estimate off by 4.5-fold (0.65 log units), on the low side, and the stated range ends below it.
By their numbers in this assay, from the lowest: compound 2; then compound 3; then compound 1; then compound 4.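

In this assay this position proves sensitive to the swap, with a 2.9-fold higher number from compound 1 to compound 4 (0.46 log units; beyond the scatter) marking a real move toward weaker inhibition. Methoxy and formyl have the same count of heavy atoms and hydrogen-bond acceptors, so those counts alone do not set the result here. Nothing measured here accounts for this step.

On these data alone, it remains open whether an amine or a carboxylic acid at this position would give a number nearer compound 1 or compound 4. As far as these compounds go, it is also open whether the swap would give a similar step with the amine rings of compound 2 and compound 3.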